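Swapping Acetyl for Dimethylamino on a Shared Core

This account rests on a few compounds, and the source may have more. Where it says the series, first, only, none or still open, it means among the compounds named here.

In a functional assay on T47D cells (Homo sapiens) for cytotoxicity, read by sulforhodamine B assay, with a stated time of 48 h, tested at 0.001 uM (a lower number here means a stronger effect, a higher number a weaker effect of the compound at the concentration tested), the three measured compounds gave:
compound 1, `COc1cc(C)cc(-c2c(-c3ccnc(-c4ccc(C(C)=O)cc4)c3)cnn2CC#N)c1`: 93%
compound 2, `Cc1cc(O)cc(-c2nn(CC#N)cc2-c2ccnc(-c3ccc(Oc4ccccc4)cc3)c2)c1`: 95%
compound 3, `Cc1cc(O)cc(-c2nn(CC#N)cc2-c2ccnc(-c3ccc(N(C)C)cc3)c2)c1`: 93%

All three numbers sit close together, and none of the gaps between them is larger than the usual scatter. Compound 1 stands level with compound 3 at the digits printed, and the two of them together give the lowest numbers of the three; compound 2 lies only a little higher, still within the scatter.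

The unmeasured compound 4, `COc1cc(C)cc(-c2c(-c3ccnc(-c4ccc(N(C)C)cc4)c3)cnn2CC#N)c1`, differs from compound 1 in one place: dimethylamino in place of acetyl on an aromatic carbon. Read one bond further out, the change is from 4-acetylphenyl to 4-(dimethylamino)phenyl.

For the measured compounds named here, the only measured step that speaks to this change is the one from compound 2 to compound 3, where dimethylamino entered on an aromatic carbon in place of phenoxy: a number 2 percentage points lower from compound 2 to compound 3 (within the scatter). Since that move stayed within the scatter, compound 4 is expected to stay near compound 1 in this assay, with a step of no change at the digits printed from compound 1 to compound 4 (within the scatter) that does not rise beyond the scatter. The estimate for compound 4 is therefore 93%, expected to fall between 85% and 100%.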

Compound 4, a percentage reported as activity, at one concentration (the size of the read-out at that concentration, not a potency): 90%
Compound 4: middle estimate off by 3 percentage points, on the high side, and the stated range covers the measured number.
By their numbers in this assay, from the lowest: compounds 4, 1, 3 and 2 (each within the scatter of the next).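

Dimethylamino in place of acetyl on this aromatic carbon, with both groups having the same count of heavy atoms, gives a number 3 percentage points lower from compound 1 to compound 4 (within the scatter) in this assay. Together with a number 2 percentage points lower from compound 2 to compound 3 (within the scatter), this means that none of the three groups read at this position, phenoxy, acetyl and dimethylamino, is separated from dimethylamino beyond the scatter in its own matched pair, and the swap from acetyl adds a direct reading to the one from phenoxy. Nothing available gives a reason for this result or tells what the swap does beyond this one read-out.

The compounds shown leave open whether a carboxylic acid, a primary amine or a longer alkyl chain at this position would move the number beyond the scatter. They also leave open whether these matched pairs would separate at higher concentrations.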